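A Methoxy Step Repeated on a Second Core

The source may report more compounds than this note shows. Statements on the series, on what has been measured and on what is new or still open speak of the compounds shown alone.

Measured compounds:
Compound 1, `COc1cccc(-c2cccc(NC(=O)CCc3ccc4c(c3)B(O)OC4)c2)c1`: 49000 nM
Compound 2, `COc1cc(OC)cc(-c2cccc(NC(=O)CCc3ccc4c(c3)B(O)OC4)c2)c1`: 21000 nM
Compound 3, `COc1cccc(-c2cccc(NC(=O)CCc3ccc4c(c3)COB4O)c2)c1`: 90000 nM

All three were tested in a functional assay on MDA-MB-231 cells (Homo sapiens) for antiproliferative activity, read by MTT assay, with a stated time of 72 h; on this read-out higher numbers stand for weaker inhibition and lower numbers for stronger inhibition. Compound 1 and compound 2 share one core and differ in a single place, (methoxy in place of hydrogen on an aromatic carbon). That change gives a 2.3-fold lower number from compound 1 to compound 2 (0.37 log units; beyond the scatter), a modest gain that lies beyond the usual scatter.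

Compound 3 carries the other core; the difference between the two cores is not broken down here. In this assay compound 3 gives 90000 nM, a number that sits within the scatter of the value of compound 1, so no order between those two can be read. Against compound 2 the gap is wider, with compound 2 giving the lower number.

Compound 4, `COc1cc(OC)cc(-c2cccc(NC(=O)CCc3ccc4c(c3)COB4O)c2)c1`, has not yet been measured. It stands to compound 3 as compound 2 stands to compound 1: the change is methoxy in place of hydrogen on an aromatic carbon, and its place reads word for word as in the earlier pair, so this is the same change on the second core. The step from compound 3 to compound 4 is expected to be about a 2.3-fold lower number from compound 3 to compound 4 (0.35 log units; beyond the scatter) in this assay, resting on the step seen between compound 1 and compound 2, a 2.3-fold lower number from compound 1 to compound 2 (0.37 log units; beyond the scatter), since only that one repeat is available. Compound 4 is therefore estimated at 40000 nM, likely between 18000 nM and 90000 nM.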

Compound 4, half-maximal inhibitory concentration: 77000 nM
The estimate for compound 4 lay 1.9-fold (0.28 log units) below the measured number; measured number inside the range.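

On the second core the added methoxy, which turns 3-methoxyphenyl into 3,5-dimethoxyphenyl, gives in this assay a 1.2-fold lower number from compound 3 to compound 4 (0.07 log units; within the scatter), so no order can be read for this pair, whereas the same change on the core of compound 1 gave a step beyond the scatter. With the 3,5-dimethoxyphenyl group held constant, the change of core gives a 3.7-fold higher number from compound 2 to compound 4 (0.56 log units; beyond the scatter), so the core still counts in this pair. Set side by side, the two methoxy steps look different in size, yet the data show neither that the gain carries over to the second core nor that it is lost, and with a single pair on each core they give no rule for other cores: the same change on two cores in this assay, a 2.3-fold lower number (0.37 log units; beyond the scatter) from compound 1 to compound 2 and a 1.2-fold lower number (0.07 log units; within the scatter) from compound 3 to compound 4, 2.0-fold (0.30 log units) apart, within the scatter of two such steps.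

The compounds shown carry only methoxy groups on the phenyl group and a single chain length leading to the amide, so it remains open how an amine, a carboxylic acid or a longer chain would behave on either core. All of these numbers also come from one cell line, which leaves open whether the picture would hold in other cells.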